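This account rests on a few compounds, and the source may have more. Where it says the series, first, only, none or still open, it means among the compounds named here.

Compound 1 (`COc1cc(NC(C)CCCNC(=O)NCCO)c2ncccc2c1`), compound 2 (`COc1cc(NC(C)CCCNC(=O)NC(CO)(CO)CO)c2ncccc2c1`) and compound 3 (`COc1cc(NC(C)CCCNC(=O)N(CCO)CCO)c2ncccc2c1`) share one core and differ only in the hydroxy-bearing groups on the urea-like end of the chain. In a functional assay on NCI-H460 cells (Homo sapiens) (on this read-out lower numbers stand for stronger inhibition and higher numbers for weaker inhibition), compound 1 gives > 100000 nM, which is a limit of the assay and not a number. Compound 2 gives > 100000 nM, which is also a limit. Compound 3 gives > 100000 nM, again a limit. The whole set therefore sits together: the limit of > 100000 nM in this assay, at which 3 of the 3 values shown sit. Compound 3 has no number of its own, only this limit.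

Compound 4 (`CCOC(=O)NCCCC(C)Nc1cc(OC)cc2cccnc12`) has ethoxy in place of bis(2-hydroxyethyl)amino on a carbonyl carbon. For the measured compounds named here, two measured steps bear on this place: a step that the two limits leave unreadable from compound 1 to compound 3 and a step that the two limits leave unreadable from compound 2 to compound 3. Neither has a readable size, and neither puts ethoxy on the carbonyl carbon, so they give no direction. The expectation rests on the structural change alone: compound 4 loses the 2-hydroxyethyl groups that compounds 1 and 3 carry, and it is the only one of the four without hydroxy groups. A cautious guess is therefore a move towards stronger inhibition, with the expected step being an at least 1.6-fold lower number from compound 3 to compound 4 (0.22 log units; that floor lies within the scatter). For compound 4 the estimated value is 60000 nM, with an expected range from 15000 nM to 200000 nM.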

Compound 4, half-maximal inhibitory concentration: 38000 nM
Estimate against measurement, compound 4: 1.6-fold (0.20 log units) above, within the range that was stated.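

In this assay, the group on the carbonyl carbon can now be seen to matter, since ethoxy in place of bis(2-hydroxyethyl)amino gives an at least 2.6-fold lower number from compound 3 to compound 4 (0.42 log units; beyond the scatter). The same holds against the other two hydroxy-bearing groups: ethoxy in place of (2-hydroxy-1,1-bis(hydroxymethyl)ethyl)amino gives an at least 2.6-fold lower number from compound 2 to compound 4 (0.42 log units; beyond the scatter), and ethoxy in place of (2-hydroxyethyl)amino gives an at least 2.6-fold lower number from compound 1 to compound 4 (0.42 log units; beyond the scatter). The steps among compounds 1, 2 and 3 cannot be read, compound 4 alone has a number rather than a limit, and each of its three steps gives only the smallest possible size, with the true size left unknown: the limit of > 100000 nM in this assay, at which 3 of the 4 values shown sit.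

The swap changes two things at once, the nitrogen attached to the carbonyl carbon and the hydroxy groups, and a diethylamino group or a 2-hydroxyethoxy group in this place would help to separate the two. As far as these compounds go, whether a longer chain on the oxygen, such as butoxy or benzyloxy, would bring the number lower than in compound 4 also remains open.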